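Acid-to-acylsulfonamide exchange on a diaryl urea series

The source may report more compounds than this note shows. Statements on the series, on what has been measured and on what is new or still open speak of the compounds shown alone.

Measured compounds:
compound 1 `Cc1ccc(NC(=O)Nc2cc(-c3ccccc3C(=O)O)ccc2Nc2ccccc2C(C)(C)C)cc1`: 600 nM
compound 2 `Cc1ccc(NC(=O)Nc2cc(-c3ccccc3C(=O)O)ccc2N(CC(C)C)CC(C)C)cc1`: 13 nM

In an assay on HeLa cells for inhibition of Indoleamine 2,3-dioxygenase 1 (Homo sapiens), with stated times of 1 h and 18 h (on this read-out lower numbers stand for stronger inhibition and higher numbers for weaker inhibition), compound 2 gives the lower of the two numbers; compound 1 sits at the higher one, and the change from compound 1 to compound 2 reads a 46-fold lower number from compound 1 to compound 2 (1.66 log units; beyond the scatter), a change at the amino substituent of the shared core. Compound 3 `Cc1ccc(NC(=O)Nc2cc(-c3ccccc3C(=O)NS(=O)(=O)C(F)(F)F)ccc2N(CC(C)C)CC(C)C)cc1` keeps the diisobutylamino group of compound 2 and alters the carboxy end instead: ((trifluoromethyl)sulfonyl)amino in place of hydroxy on a carbonyl carbon.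

Among the measured compounds shown here, no measured pair covers this exchange; the one recorded step concerns a different position, so it offers no guide to the size or direction here. The expectation for compound 3 is therefore anchored on compound 2 with a wide band. Compound 3 is expected to remain near compound 2 in this assay, at roughly 15 nM, between 4 nM and 60 nM, which means an estimated step of a 1.2-fold higher number from compound 2 to compound 3 (0.06 log units; within the scatter), not clearly beyond the scatter.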

Compound 3, half-maximal inhibitory concentration: > 1000 nM
Compound 3: only a limit was reported; the forecaster's own chance of this, stated with the estimate: 2%; at least 66-fold (1.82 log units) between middle value and limit.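

The carboxy end, unchanged across compounds 1 and 2, is now shown to be a sensitive position: with the diisobutylamino group held constant, ((trifluoromethyl)sulfonyl)amino in place of hydroxy on a carbonyl carbon gives an at least 76-fold higher number from compound 2 to compound 3 (1.88 log units; beyond the scatter) in this assay. The amino substituent of the shared core is therefore not the only site of a large step, and this exchange reverses the gain seen at that site, where the recorded change was a 46-fold lower number from compound 1 to compound 2 (1.66 log units; beyond the scatter). The reading for compound 3 is a limit of the assay and not a number, so the true size of its step stays unknown: the limit of > 1000 nM in this assay, at which 1 of the 3 values shown sits.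

The compounds shown leave open whether the loss follows from the trifluoromethyl group or from the sulfonylamino link itself, which a methylsulfonyl analogue, a primary amide or a tetrazole in place of the carboxy group would help separate. From the compounds shown here alone, it is also open whether the same exchange would read alike with the (2-(tert-butyl)phenyl)amino group of compound 1 in place of diisobutylamino.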